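A few compounds are considered here, and "the series" means these few. Any claim that something is new, unique, unknown or untested is made for them only; others in the source may bear on it.

Measured so far:
compound 1, `COCC(C(=O)N1CCN(c2cccc(C(F)(F)F)c2)CC1)N1C(=O)CCC1=O`: 100%
compound 2, `CC(C(=O)N1CCN(c2cccc(Cl)c2)CC1)N1C(=O)CCC1=O`: 50%
compound 3, `CCC(C(=O)N1CCN(c2cccc(C(F)(F)F)c2)CC1)N1C(=O)CCC1=O`: 50%

In a functional assay on the whole organism (strain Swiss) with Mus musculus as the target, in the maximal electroshock model, with a stated time of 2 h, at a dose of 300 mg/kg by the intraperitoneal route (a lower number here means a weaker effect, a higher number a stronger effect of the compound at the dose given), compound 3 gives 50%. Within the data shown here, compound 3 stands level with compound 2 at the digits given, and the two together sit lowest of the three numbers; compound 1 sits highest, and the only single-point step measured, a number 50 percentage points lower from compound 1 to compound 3 (beyond the scatter), is a large drop.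

The next compound, compound 4, `CC(C(=O)N1CCN(c2cccc(C(F)(F)F)c2)CC1)N1C(=O)CCC1=O`, differs from compound 3 by hydrogen in place of methyl on a saturated chain carbon, two bonds along the chain from an amide-type nitrogen in a ring and a carbonyl carbon. Among the measured compounds shown here, no measured step covers this exact exchange. The step from compound 1 to compound 3 concerns the same place, but it swaps methoxy for methyl, not methyl for hydrogen, so it tells only that this place can move the result a long way. Compound 2 carries hydrogen at that place yet differs elsewhere from the next compound, so the value of compound 2, 50%, serves only as a loose hint.

Compound 4 is therefore expected to stay close to compound 3, with a step of about no change at the digits printed from compound 3 to compound 4 (within the scatter) in this assay, inside the scatter. The estimate for compound 4 is 50%, ranging from 20% to 90%.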

Compound 4, a percentage reported as activity, at one dose (the size of the read-out at that dose, not a potency): 100%
For compound 4 the middle estimate is 50 percentage points below the measured one; measured number above the stated range.
By their numbers in this assay, from the lowest: compounds 2 and 3 (each within the scatter of the next); then compounds 1 and 4 (each within the scatter of the next).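

In this assay this chain carbon proves highly sensitive to one small exchange, with hydrogen in place of methyl giving a number 50 percentage points higher from compound 3 to compound 4 (beyond the scatter), while hydrogen in place of methoxy gives no change at the digits printed from compound 1 to compound 4 (within the scatter), so the read-out does not move steadily as the group here goes from hydrogen through methyl to methoxy. The aromatic carbon matters as well: with hydrogen on the chain carbon, trifluoromethyl in place of chloro gives a number 50 percentage points higher from compound 2 to compound 4 (beyond the scatter). No measurement here offers an explanation for either large step.

Going by these compounds, how a longer chain such as propyl, or an amine, would behave on this chain carbon remains open. So does the effect of a nitrile in place of trifluoromethyl on the aromatic carbon.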